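A few compounds are considered here, and "the series" means these few. Any claim that something is new, unique, unknown or untested is made for them only; others in the source may bear on it.

Three compounds have been measured in a functional assay on L1210 cells (Mus musculus) for inhibition; on this read-out higher numbers stand for weaker inhibition and lower numbers for stronger inhibition:

Compound 1 `C=C1[C@@H](O)[C@H](n2ccc(=O)[nH]c2=O)O[C@@H]1CO`: > 500000 nM, a limit of the assay and not a number.
Compound 2 `C=C1C(n2ccc(N)nc2=O)O[C@H](CO)[C@@H]1O`: 2000 nM.
Compound 3 `C=C1[C@@H](O)[C@H](n2cnc3c(Cl)nc(N)nc32)O[C@@H]1CO`: 441000 nM.

Among the two actual numbers, compound 3 stands higher, and its gap to compound 2 lies beyond the usual scatter of repeated measurements. It therefore sits at the weak end of the numbers in this assay, while compound 2 shows the stronger inhibition.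

The next compound to be tested is compound 4 `C=C1[C@@H](O)[C@H](n2cnc3c(N)nc(N)nc32)O[C@@H]1CO`. It differs from compound 3 at a single place: amino replaces chloro on an aromatic carbon, next to the ring nitrogen of the six-membered aromatic ring with 2 nitrogen (amino in place of chloro on an aromatic carbon). Within the data shown here, no measured pair shows this change, so the size of the step cannot be read from the data. A modest move toward a lower number is expected, possibly not far beyond the scatter. Compound 3, at 441000 nM, is the starting point for this expectation, and a drop to the level of compound 2 is not anticipated. The expected change is a 2.9-fold lower number from compound 3 to compound 4 (0.47 log units; beyond the scatter). For compound 4 the estimated value is 150000 nM, with an expected range of 30000 nM to 500000 nM.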

Compound 4, half-maximal inhibitory concentration: > 200000 nM
Compound 4 was reported as a limit (the forecaster's own chance of this, stated with the estimate: 20%); middle value at least 1.3-fold (0.12 log units) away from the limit.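

Among these compounds, compound 4 is reported in this assay only as a limit and not a number, so no step from compound 3 to compound 4 can be read: the limit of > 200000 nM in this assay, at which 1 of the 4 values shown sits. The compounds shown leave open how far, if at all, amino in place of chloro on an aromatic carbon changes the inhibition.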